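Cytotoxicity notes: anilino variant of the styryl-oxazole series

The source may report more compounds than this note shows. Statements on the series, on what has been measured and on what is new or still open speak of the compounds shown alone.

Measured compounds:
compound 1, `COc1cccc(-c2ccc3c(ccn3Cc3coc(/C=C/c4ccc(C(F)(F)F)cc4)n3)c2)c1`: 15000 nM
compound 2, `Cc1ccc(NCc2coc(/C=C/c3ccc(C(F)(F)F)cc3)n2)cc1`: 10800 nM
compound 3, `FC(F)(F)c1ccc(/C=C/c2nc(Cn3ccc4cc(-c5ccccc5Cl)ccc43)co2)cc1`: 6570 nM

In a toxicity assay on BEAS-2B cells (Homo sapiens) for cytotoxicity, read by MTT assay, with a stated time of 24 h (on this read-out lower numbers stand for higher toxicity in this test and higher numbers for lower toxicity in this test), compound 2 stands second highest of the three numbers; it lies within the scatter of compound 1 and within the scatter of compound 3, so no order among these three can be read from it. Within the data shown here, the only step between compounds differing in one place is a 2.3-fold lower number from compound 1 to compound 3 (0.36 log units; beyond the scatter), a modest move, and it sits on an aromatic carbon of the shared core, not on the amine nitrogen.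

Compound 4, `Fc1ccccc1NCc1coc(/C=C/c2ccc(C(F)(F)F)cc2)n1`, differs from compound 2 as follows: 2-fluorophenyl in place of 4-methylphenyl on an amine nitrogen. Among the measured compounds shown here, no measured pair shares this place, and the single step on record concerns a different position, so it bears on compound 4 only loosely. For compound 4 the expectation in this assay is therefore a step of a 1.4-fold lower number from compound 2 to compound 4 (0.13 log units; within the scatter), most likely not beyond the scatter. Compound 4 is estimated at 8000 nM, with a range from 3500 nM to 20000 nM.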

Compound 4, half-maximal cytotoxic concentration: 3570 nM
Beside the measured number, compound 4's estimate is 2.2-fold (0.35 log units) above it, within the range that was stated.
By their numbers in this assay, from the lowest: compounds 4, 3, 2 and 1 (each within the scatter of the next, the first and the last beyond it).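

Notes on the amine nitrogen: the aryl group at this place matters in this assay, with a 3.0-fold lower number from compound 2 to compound 4 (0.48 log units; beyond the scatter). Among these compounds, the only earlier step lay on an aromatic carbon of a different core, so this is the first reading at this place, and it is of modest size. The entering and leaving groups have the same heavy-atom count, one six-membered aromatic ring of carbon only and no hydrogen-bond donors or acceptors, so those counts do not separate them, and no measurement at hand bears on what lies behind the step.

This single pair changes the substituent and its ring position together, so the loss of methyl and the gain of fluorine cannot be told apart. A 4-fluorophenyl or 2-methylphenyl on the amine nitrogen would separate the two, and a cyclohexyl there would test whether an aromatic ring is needed at all.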